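Replacing a methyl with hydroxy on compound 3

The source may hold more compounds than are shown below. What is called first, only, known or untested is meant among the compounds shown, and "the series" means these compounds.

Compound 1 `COc1cc(C(=O)c2cccc3[nH]ccc23)cc(OC)c1OC`: 54.4 nM
Compound 2 `COc1cc(C(=O)c2cccc3cc[nH]c23)cc(OC)c1OC`: 310 nM
Compound 3 `CCn1ccc2cc(C(=O)c3cc(OC)c(OC)c(OC)c3)ccc21`: 41 nM

In a functional assay on TSGH cells (Homo sapiens) for inhibition, with a stated time of 72 h (a lower number here means a stronger inhibitor, a higher number a weaker inhibitor), compound 3 gives 41 nM, which lies within the scatter of compound 1 at 54.4 nM. Compound 2, at 310 nM, is a clearly weaker inhibitor than compound 3. Compound 4 `COc1cc(C(=O)c2ccc3c(ccn3CO)c2)cc(OC)c1OC` carries hydroxy in place of methyl on a saturated chain carbon bound to an aromatic nitrogen, so that ethyl becomes hydroxymethyl: hydroxy in place of methyl on a saturated chain carbon bound to an aromatic nitrogen. For the measured compounds named here, no measured pair isolates this change, so the expectation is loose. The expected 2.7-fold higher number from compound 3 to compound 4 (0.43 log units; beyond the scatter) is modest and points toward a higher number, though it may stay within the scatter. For compound 4 the estimated value in this assay is 110 nM, with an expected range of 35 nM to 350 nM.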

Compound 4, half-maximal inhibitory concentration: 43 nM
Estimate against measurement, compound 4: 2.6-fold (0.41 log units) above; the range from low to high includes it.
By their numbers in this assay, from the lowest: compounds 3, 4 and 1 (each within the scatter of the next); then compound 2.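

Ethyl to hydroxymethyl on this nitrogen gives a 1.0-fold higher number from compound 3 to compound 4 (0.02 log units; within the scatter) in this assay and so the two compounds cannot be told apart. For the compounds shown here, this is the first sign that hydroxy in place of methyl on a saturated chain carbon bound to an aromatic nitrogen is accepted here, with compound 4 as potent as compound 3 within the scatter. From the compounds shown here alone, whether an amine, a carboxylic acid or a longer chain ending in hydroxy at this place would do the same stays open. Nothing shown gives a reason for this result.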